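Amide side-chain variation in a weak-binding series

The compounds below may be only part of what the source reports. "The series", "measured", "known", "first", "only" and "open" are said of these compounds alone.

Compound 2 `NCCC(=O)N1CCN(CCCOc2ccc(C(=O)C3CC3)cc2)CC1` gives 100000 nM in an assay for binding affinity to histamine H2 receptor (Homo sapiens) (a higher number here means a weaker inhibitor, a lower number a stronger inhibitor), and compound 1 `CCC[C@@H](N)C(=O)N1CCN(CCCOc2ccc(C(=O)C3CC3)cc2)CC1` gives 60300 nM in this assay; the step of a 1.7-fold higher number from compound 1 to compound 2 (0.22 log units; within the scatter) lies within the scatter, so the two stand together at the weak end. Compound 3 `CN[C@@H](C(=O)N1CCN(CCCOc2ccc(C(=O)C3CC3)cc2)CC1)C(C)C` differs from compound 2 by 2-methyl-1-(methylamino)propyl in place of 2-aminoethyl on a carbonyl carbon. Among the measured compounds shown here, the only step bearing on this change, a 1.7-fold higher number from compound 1 to compound 2 (0.22 log units; within the scatter), also altered the group on that carbonyl carbon and produced nothing beyond the scatter, so no step beyond the scatter is expected here. Compound 3 is therefore estimated at 70000 nM, range 25000 nM to 200000 nM, a step of a 1.4-fold lower number from compound 2 to compound 3 (0.15 log units; within the scatter).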

Compound 3, inhibition constant: 49000 nM
Beside the measured number, compound 3's estimate is 1.4-fold (0.15 log units) above it; low and high end bracket the measured number.
By their numbers in this assay, from the lowest: compounds 3, 1 and 2 (each within the scatter of the next, the first and the last beyond it).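

Among the compounds shown here, on the carbonyl carbon whose other neighbour is the amide-type nitrogen in a ring, 2-methyl-1-(methylamino)propyl in place of 2-aminoethyl gives the first step in this assay to pass the scatter (a 2.0-fold lower number from compound 2 to compound 3 (0.31 log units; beyond the scatter)), though it is modest. Against 1-aminobutyl, the same group stays within the scatter (a 1.2-fold lower number from compound 1 to compound 3 (0.09 log units; within the scatter)), so these two groups cannot be told apart here. No data on the origin of this small step are available.

The compounds shown do not separate the methylamino part from the rest of the entering group. On these data alone, whether a carboxylic acid or a longer amine chain at this place would leave the weak end stays open.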